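The source may hold more compounds than are shown below. What is called first, only, known or untested is meant among the compounds shown, and "the series" means these compounds.

Compound 1 `N#Cc1c(N2CCCCC2)c2sc3ccccc3c2n2c1nc1ccccc12` gives 8.34 in a physicochemical assay for lipophilicity, read by HPLC, at pH 7.4; on this read-out lower numbers stand for lower lipophilicity and higher numbers for higher lipophilicity. Compound 2 `CN(C)CCCNc1c(C#N)c2nc3ccccc3n2c2c1sc1ccccc12` carries the change ((3-(dimethylamino)propyl)amino in place of piperidin-1-yl on an aromatic carbon). In this assay compound 2 gives 3.44, so that a number 4.90 log units lower from compound 1 to compound 2 (beyond the scatter). Compound 3 `N#Cc1cc2sc3cc(N4CCCCC4)ccc3c2n2c1nc1ccccc12` gives 8.5 in this assay; the difference between the cores of compound 1 and compound 3 is not broken down here, and their two values lie within the scatter of each other. Compound 4 `CN(C)CCCNc1ccc2c(c1)sc1cc(C#N)c3nc4ccccc4n3c12` is not yet measured and carries the change ((3-(dimethylamino)propyl)amino in place of piperidin-1-yl on an aromatic carbon). This is the same kind of change as in compound 2, but the place differs: in compound 2 it sits on a six-membered aromatic ring with one nitrogen, ortho to a cyano group, ortho to a fused ring and opposite the ring nitrogen, whereas in compound 4 it sits on a six-membered aromatic ring of carbon only, meta to a fused ring and para to a fused ring. In this assay a step of similar size, a number 4.80 log units lower from compound 3 to compound 4 (beyond the scatter), is expected, resting on the earlier step of a number 4.90 log units lower from compound 1 to compound 2 (beyond the scatter). Compound 4 is therefore estimated at 3.7, between 2.9 and 4.6.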

Compound 4, distribution coefficient: 2.91
Compound 4: middle estimate off by 0.79 log units, on the high side; low and high end bracket the measured number.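

In this assay the change from piperidin-1-yl to (3-(dimethylamino)propyl)amino is large and goes the same way on both cores (a number 5.59 log units lower from compound 3 to compound 4 (beyond the scatter); a number 4.90 log units lower from compound 1 to compound 2 (beyond the scatter)). The direction and broad size of the step therefore carry over between these two cores and places, but two pairs do not show that this holds on any other core or at any other place. Nothing shown explains the size of either step or ties it to a part of the chain.

The compounds shown leave open which part of the entering group goes with the step. A morpholin-4-yl ring, a longer chain ending in dimethylamino or a chain ending in a carboxylic acid could help to separate these parts.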